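From a fluoro to an ethyl group on the phenyl ring

The compounds below may be only part of what the source reports. "The series", "measured", "known", "first", "only" and "open" are said of these compounds alone.

Measured so far in an in vitro functional assay on CHO/Galpha16 cells for antagonist activity at C-C chemokine receptor type 8 (Homo sapiens), read by FLIPR; a lower number here means a stronger inhibitor, a higher number a weaker inhibitor:
compound 1 `CCCC(=O)N1CCC(NS(=O)(=O)c2ccc(NC(=O)C(CC)CC)c3ccccc23)CC1` gives 639 nM
compound 2 `CCCC(=O)N1CCC(NS(=O)(=O)c2ccc(NC(=O)c3ccc(F)cc3)c3ccccc23)CC1` gives 59.5 nM

Compound 2 has the lower of the two numbers; its nearest neighbour is compound 1, and the step of an 11-fold lower number from compound 1 to compound 2 (1.03 log units; beyond the scatter) separates them. Compound 3 `CCCC(=O)N1CCC(NS(=O)(=O)c2ccc(NC(=O)c3ccc(CC)cc3)c3ccccc23)CC1` has not yet been measured. It differs from compound 2 in one place: ethyl in place of fluoro on an aromatic carbon.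

Within the data shown here, the only measured step, that from compound 1 to compound 2, exchanges the whole group attached to the carbonyl carbon, an alkyl chain against an aromatic ring. It does not compare two different substituents sitting at the same place on that ring, so it says nothing direct about replacing fluoro by ethyl. Among the measured compounds shown here, with no step of that kind in hand, the expectation for compound 3 rests on compound 2 alone, and the step of a 1.2-fold higher number from compound 2 to compound 3 (0.07 log units; within the scatter) is expected to stay within the scatter of repeated measurements. Compound 3 is therefore estimated at 70 nM in this assay, with a range from 20 nM to 250 nM.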

Compound 3, half-maximal inhibitory concentration: 10.8 nM
Estimate against measurement, compound 3: 6.5-fold (0.81 log units) above, and the stated range ends above it.
By their numbers in this assay, from the lowest: compound 3; then compound 2; then compound 1.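

In this assay, the group para to a large group on the phenyl ring clearly matters: putting ethyl in place of fluoro gives a 5.5-fold lower number from compound 2 to compound 3 (0.74 log units; beyond the scatter). The earlier compounds shown here showed only that exchanging pentan-3-yl for 4-fluorophenyl lowers the number, and the step with 4-ethylphenyl as the replacement is larger, at a 59-fold lower number from compound 1 to compound 3 (1.77 log units; beyond the scatter), so the size of this gain depends on what the phenyl ring carries and not only on the ring being there. Nothing available here bears on why ethyl does better than fluoro at this place.

With only fluoro and ethyl to compare at this place, the compounds shown do not tell whether a longer chain such as propyl would lower the number further or raise it again, or what an amine or a carboxylic acid would do there. They also leave open whether ethyl in place of fluoro would give a similar step if another part of the shared core were changed.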